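Sulfoxide series: amide substituent at the piperidine nitrogen

A few compounds are considered here, and "the series" means these few. Any claim that something is new, unique, unknown or untested is made for them only; others in the source may bear on it.

Measured compounds:
compound 1 `Fc1ccc(C(SCCNC2CCN(Cc3ccccc3)CC2)c2ccc(F)cc2)cc1` — 3.81 nM
compound 2 `O=C(c1ccccc1)N1CCC(NCC[S+]([O-])C(c2ccc(F)cc2)c2ccc(F)cc2)CC1` — 585 nM

In an assay on membranes from Cortex for displacement of a labelled ligand from Sigma non-opioid intracellular receptor 1 (Cavia porcellus), read by scintillation counting, with a stated time of 120 min (on this read-out lower numbers stand for stronger inhibition and higher numbers for weaker inhibition), compound 2 gives 585 nM, the higher of the two numbers; compound 1 gives 3.81 nM, and the gap between the two lies beyond the scatter. Within the data shown here, no pair of measured compounds differs in only one place, so no step of known size is available.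

Compound 3 `CC(C)(C)C(=O)N1CCC(NCC[S+]([O-])C(c2ccc(F)cc2)c2ccc(F)cc2)CC1` keeps the sulfoxide and the piperidine of compound 2 and changes only the amide substituent: tert-butyl in place of phenyl on a carbonyl carbon. Nothing measured here isolates an amide change of this sort, so the expected step carries no reference of its own. Compound 3 is expected to stay close to compound 2, with a step of a 1.4-fold higher number from compound 2 to compound 3 (0.14 log units; within the scatter) that may well be no larger than the scatter. Compound 3 is therefore estimated at 800 nM, within a range from 200 nM to 3200 nM.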

Compound 3, inhibition constant: 11200 nM
Compound 3: middle estimate off by 14-fold (1.15 log units), on the low side, outside the stated range (above it).
By their numbers in this assay, from the lowest: compound 1; then compound 2; then compound 3.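

The amide substituent is a sensitive place in this series: in this assay, tert-butyl in place of phenyl on a carbonyl carbon gives a 19-fold higher number from compound 2 to compound 3 (1.28 log units; beyond the scatter), a large step beyond the scatter. Among these compounds, this is the first single-place change, and it shows that retaining the amide carbonyl and the rest of compound 2 does not preserve the value when the six-membered aromatic ring is replaced by a group with no ring. Nothing at hand accounts for the size of this step.

The compounds shown cannot separate loss of the aromatic ring from the change to a branched group, and a cyclohexyl or a pyridyl group on the same carbonyl carbon would address that question. Among the compounds shown here, compound 1 and compound 2 differ in more than one place, so no step between them can be read.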